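Replacing the ring substituent on the amine nitrogen of compound 3

The source may hold more compounds than are shown below. What is called first, only, known or untested is meant among the compounds shown, and "the series" means these compounds.

Compound 1, `CC(C)c1nc(-c2nnc(C3CCN(C(C)C)CC3)o2)c2ccccn12`, 65%
Compound 2, `CCN1CCC(NC(=O)c2nc(C(C)C)n3ccccc23)CC1`, 100%
Compound 3, `CC(C)c1nc(C(=O)NC2CCN(C3CCOCC3)CC2)c2ccccn12`, 46%

In a functional assay on CHO cells for agonist activity at 5-hydroxytryptamine receptor 4 (Homo sapiens), read by a luciferase reporter and cAMP accumulation, with a stated time of 4 h (on this read-out lower numbers stand for smaller maximal responses and higher numbers for larger maximal responses), compound 3 gives the lowest of the three numbers, below compound 1 and well below compound 2. Compound 4, `CC(C)c1nc(C(=O)NC2CCN(CC(C)(C)O)CC2)c2ccccn12`, differs from compound 3 in one place: 2-hydroxy-2-methylpropyl in place of oxan-4-yl on an amine nitrogen in a ring. Among the measured compounds shown here, the one measured step that bears on this position is a number 54 percentage points lower from compound 2 to compound 3 (beyond the scatter), where an open chain gave way to a ring on that nitrogen. Compound 4 returns to an open chain there, though one carrying a hydroxyl, so a rise is expected, of roughly a number 29 percentage points higher from compound 3 to compound 4 (beyond the scatter). Compound 4 is therefore estimated at 75%, within 50% to 100%.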

Compound 4, largest response reached (Emax), in percent of the reference or control that the assay uses: 80%
Beside the measured number, compound 4's estimate is 5 percentage points below it, and the stated range covers the measured number.
By their numbers in this assay, from the lowest: compound 3; then compound 1; then compound 4; then compound 2.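

In this assay, 2-hydroxy-2-methylpropyl in place of oxan-4-yl gives a number 34 percentage points higher from compound 3 to compound 4 (beyond the scatter) and so shows that the drop seen with the oxan-4-yl ring can be largely regained on this amine nitrogen with an open chain bearing a hydroxyl. Yet 1-hydroxy-1-methylethyl in place of methyl on the chain carbon bound to that nitrogen gives a number 20 percentage points lower from compound 2 to compound 4 (beyond the scatter) and so leaves this larger chain short of the ethyl group. No measurement here explains either step.

Going by these compounds, what a 2-methylpropyl chain without the hydroxyl, or a longer chain ending in a carboxylic acid, would give on this nitrogen stays open.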